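2-fluorobenzyl to 4-cyanobenzyl at a solubility limit

A few compounds are considered here, and "the series" means these few. Any claim that something is new, unique, unknown or untested is made for them only; others in the source may bear on it.

Measured in a physicochemical assay for solubility, using the shake flask method, in simulated intestinal fluid, measured as kinetic solubility, with a stated time of 2 h, at 25 degrees C, at pH 6.5; on this read-out higher numbers stand for higher solubility and lower numbers for lower solubility:
Compound 1 `Cc1noc(-c2nc(C)c3c(c2N)C(=O)N(CC2CCNCC2)C3=O)n1`: 160000 nM
Compound 2 `Cc1noc(-c2nc(C)c3c(c2N)C(=O)N(Cc2ccc(Br)cc2)C3=O)n1`: < 5000 nM (a limit)
Compound 3 `Cc1noc(-c2nc(C)c3c(c2N)C(=O)N(Cc2ccccc2F)C3=O)n1`: < 5000 nM (a limit)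

Compound 3 has only a limit, < 5000 nM, and no exact number. Compound 4 `Cc1noc(-c2nc(C)c3c(c2N)C(=O)N(Cc2ccc(C#N)cc2)C3=O)n1` carries 4-cyanophenyl in place of 2-fluorophenyl on a saturated chain carbon bound to an amide-type nitrogen in a ring. Two large measured steps bear on this: an at least 32-fold lower number from compound 1 to compound 2 (1.50 log units; beyond the scatter) and an at least 32-fold lower number from compound 1 to compound 3 (1.50 log units; beyond the scatter), each replacing piperidin-4-yl with a substituted phenyl group. The closest comparison, a step that the two limits leave unreadable from compound 2 to compound 3, swaps one phenyl group for another but cannot be read. Compound 4 also keeps a phenyl group, so no step beyond the scatter is expected in this assay, and no direction can be favoured. The estimated change is a step that the limit leaves unreadable from compound 3 to compound 4. For compound 4 the expected value is 3000 nM, with an estimated range from 800 nM to 9000 nM.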

Compound 4, solubility: < 5000 nM
Compound 4 was reported as a limit; the forecaster's own chance of this, stated with the estimate: 75%; the middle value is on the limit's open side.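

Compound 4 gives < 5000 nM in this assay, and this is a limit, not a number. Putting 4-cyanophenyl in place of piperidin-4-yl on this chain carbon gives an at least 32-fold lower number from compound 1 to compound 4 (1.50 log units; beyond the scatter), so a nitrile-bearing phenyl group also ends far from compound 1. The steps among compounds 2, 3 and 4 cannot be read, and these phenyl groups cannot be ranked because all three compounds share one limit: the limit of < 5000 nM in this assay, at which 3 of the 4 values shown sit.

Still open, as far as these compounds go, is whether a phenyl group carrying an amine or a carboxylic acid would give a value clear of that limit. Also open, from the compounds shown here alone, is how a longer open alkyl chain without a ring would read at this place.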